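A few compounds are considered here, and "the series" means these few. Any claim that something is new, unique, unknown or untested is made for them only; others in the source may bear on it.

Among the measured compounds shown here, in an ADME assay on a cell-free system (plasma, Homo sapiens) for metabolic stability, read by LC-MS, with a stated time of 60 min, tested at 10 uM (a higher number here means that more of the compound is left, a lower number that less of the compound is left), two compounds have numbers so far. Compound 1 `CC(C)C[C@H](N)C(=O)N[C@@H](CCC(=O)C=[N+]=[N-])C(=O)OC(C)C` gives 1%, the lower of the two, while compound 2 `COC(=O)[C@H](CCC(=O)C=[N+]=[N-])NC(=O)OC(OC(=O)C(C)(C)C)C(C)C` gives 91%, a gap well beyond the scatter of repeated measurements. These two compounds differ in more than one place, so their gap does not size any single structural change. Compound 3 `CCOC(=O)[C@H](CCC(=O)C=[N+]=[N-])NC(=O)[C@@H](N)CC(C)C` differs from compound 1 in one place, where isopropoxycarbonyl becomes ethoxycarbonyl: hydrogen in place of methyl on a saturated chain carbon bound to an oxygen next to a carbonyl group and a saturated chain carbon. This is hydrogen in place of methyl on a saturated chain carbon bound to an oxygen next to a carbonyl group and a saturated chain carbon. For the measured compounds named here, no measured step of this kind is available as a guide, so the expectation in this assay is for no change beyond the scatter. Compound 1 at 1% leaves almost no room to fall, so any small movement would be expected to be upward. The estimated step is a number 2 percentage points higher from compound 1 to compound 3 (within the scatter). Compound 3 is expected to give 3%, with an estimated range of 0% to 15%.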

Compound 3, percent of the compound remaining: 1%
The estimate for compound 3 lay 2 percentage points above the measured number; the range from low to high includes it.
By their numbers in this assay, from the lowest: compounds 1 and 3 (each within the scatter of the next); then compound 2.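

In this assay, among the compounds shown here, replacing isopropoxycarbonyl with ethoxycarbonyl gives no change at the digits printed from compound 1 to compound 3 (within the scatter), the only measured step at this position. Compound 1 gives 1% and compound 3 gives 1%, both so close to the bottom of the read-out that a further fall could hardly be seen, so the result shows only that this shortening from isopropyl to ethyl does not lift the number out of that low range. Nothing available explains why so little of either compound is left.

Still open, as far as these compounds go, is whether any other group at this place, such as a tert-butoxycarbonyl, a longer chain or a carboxylic acid, would leave more of the compound at the end of the assay. Compound 2 at 91% differs from compound 1 and compound 3 in more than one place, so the compounds shown cannot tell which of its structural differences goes with its much higher number.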